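The source may report more compounds than this note shows. Statements on the series, on what has been measured and on what is new or still open speak of the compounds shown alone.

Among the compounds with values here, in a functional assay on MCF7 cells (Homo sapiens) for antiproliferative activity, read by MTT assay, with a stated time of 72 h (a lower number here means a stronger inhibitor of growth, a higher number a weaker inhibitor of growth), compound 3, `Cn1nc(-c2ccnc(Nc3ccc(O)cc3)n2)c2ccccc21`, gives 8910 nM, the lowest of the three numbers measured so far. Compound 2, `O=[N+]([O-])c1cccc(Nc2nc3ncccc3n2Cc2ccccc2)c1`, gives 24200 nM, and compound 1, `Brc1cccc(Nc2nc3ncccc3n2Cc2ccccc2)c1`, gives 78700 nM. Within the data shown here, the only measured step between neighbours, a 3.3-fold lower number from compound 1 to compound 2 (0.51 log units; beyond the scatter), sits on a different core and swaps a different kind of group, so it offers no direct guide to the move from compound 3 to compound 4, `Cn1nc(-c2ccnc(Nc3cccc(O)c3)n2)c2ccccc21`. That move is 3-hydroxyphenyl in place of 4-hydroxyphenyl on a nitrogen on an aromatic ring. Among the measured compounds shown here, with no comparable step on record, no shift beyond the usual scatter is expected, and the expected step is a 1.0-fold higher number from compound 3 to compound 4 (0.00 log units; within the scatter). Compound 4 is therefore estimated at 9000 nM, with a likely range from 3000 nM to 27000 nM.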

Compound 4, concentration for 50% growth inhibition: 28200 nM
Compound 4: the middle estimate sits 3.1-fold (0.50 log units) below what was measured; measured number outside the range, above it.
By their numbers in this assay, from the lowest: compound 3; then compounds 2 and 4 (each within the scatter of the next); then compound 1.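

In this assay, 3-hydroxyphenyl in place of 4-hydroxyphenyl on the nitrogen gives a 3.2-fold higher number from compound 3 to compound 4 (0.50 log units; beyond the scatter), although the group keeps the same atoms and only their arrangement differs. The earlier step replaced one group with a different one on another core, whereas this pair shows that, on this core, arrangement alone can shift growth inhibition. No measurement shown here explains the shift. Going by these compounds, whether an aminophenyl or methoxyphenyl group would match the 4-hydroxyphenyl of compound 3 remains open. So does whether this change would have a similar effect on another core.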